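The compounds below may be only part of what the source reports. "The series", "measured", "known", "first", "only" and "open" are said of these compounds alone.

Compound 1 `O=C(Nc1ncc(Cc2ccc(F)cc2)s1)C1CCCCC1`: > 50000 nM
Compound 2 `COCCc1ccc(OC(c2ccc(Cl)cc2)c2cnc(NC(=O)OC(C)(C)C)s2)cc1`: > 50000 nM
Compound 3 `Cc1ccc(COC(c2ccccc2)c2cnc(NC(=O)c3cccs3)s2)cc1`: "not toxic" (no number reported)

In an ADME assay on HepG2 2.2.15 cells (Homo sapiens) for cytotoxicity (a lower number here means that less compound is tolerated, a higher number that more compound is tolerated), compound 1 gives only a limit, > 50000 nM. Compound 2 also gives only a limit in this assay, > 50000 nM. Compound 3 is reported simply as "not toxic" (no number reported), with no number attached, so it stands where the whole set stands: nothing shown carries a measured number, and the only anchor is the limit of > 50000 nM in this assay, at which 2 of the 3 values shown sit.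

Compound 4 `COc1ccc(Br)c(COC(c2ccccc2)c2cnc(NC(=O)c3cccs3)s2)c1` has not yet been measured. It differs from compound 3 by 2-bromo-5-methoxyphenyl in place of 4-methylphenyl on a saturated chain carbon bound to an oxygen on a saturated carbon. Among the compounds with values here, no step between measured compounds exists to size this change. None of the three measured compounds gives a number in this assay, so a step of no size beyond the scatter is expected, in no particular direction. Compound 4 is estimated at 50000 nM, expected between 20000 nM and 100000 nM, and most likely reported only as a limit.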

Compound 4, half-maximal cytotoxic concentration: "not toxic" (no number reported)
The entry for compound 4 holds no number, so the estimate cannot be set against anything.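

Compound 3 and compound 4 are both reported only as "not toxic", without a number, so no step can be read between them in this assay. The compounds shown leave open at what concentration any of them becomes toxic: the limit of > 50000 nM in this assay, at which 2 of the 4 values shown sit.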